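Trimming the benzyl ether of compound 1 to an ethyl ether

The source may hold more compounds than are shown below. What is called first, only, known or untested is meant among the compounds shown, and "the series" means these compounds.

Measured compounds:
- compound 1, `O=[N+]([O-])c1ccc(COc2ccc(OCCOCCNC3CCCC3)cc2)cc1`: 20300 nM
- compound 2, `Clc1ccc(COc2ccc(OCCOCCNC3CCCCC3)cc2)cc1`: 2650 nM
- compound 3, `c1ccc(COc2ccc(OCCOCCNC3CC3)cc2)cc1`: 47200 nM

In a functional assay on SK-OV-3 cells (Homo sapiens) for inhibition, read by CCK-8 assay, with a stated time of 70 h (on this read-out higher numbers stand for weaker inhibition and lower numbers for stronger inhibition), compound 1 gives 20300 nM, the second highest of the three numbers. Its nearest neighbour is compound 3, whose number is higher by a margin beyond the scatter, and the furthest is compound 2, whose number is lower by a margin that is also beyond the scatter. Compound 1 is therefore neither the strongest nor the weakest of the three.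

The unmeasured compound 4, `CCOc1ccc(OCCOCCNC2CCCC2)cc1`, differs from compound 1 in one place: methyl in place of 4-nitrophenyl on a saturated chain carbon bound to an oxygen on an aromatic ring. Among the measured compounds shown here, no pair of measured compounds shows a step of this kind, so nothing measured speaks directly to its size. All three measured compounds carry a substituted or bare benzyl on this oxygen, and the methyl of compound 4 is a far smaller group. The author expects the step in this assay from compound 1 to compound 4 to weaken inhibition, estimated at a 2.2-fold higher number from compound 1 to compound 4 (0.35 log units; beyond the scatter), though with wide uncertainty. Compound 4 is thus expected to give about 45000 nM, in a range from 15000 nM to 150000 nM.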

Compound 4, half-maximal inhibitory concentration: 90500 nM
Compound 4: the middle estimate sits 2.0-fold (0.30 log units) below what was measured; the measured number falls inside the stated range.
By their numbers in this assay, from the lowest: compound 2; then compound 1; then compounds 3 and 4 (each within the scatter of the next).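

In this assay, among the compounds shown here, this is the first step that can be read at a single position, and it concerns the group on the saturated chain carbon bound to an oxygen on an aromatic ring. Methyl in place of 4-nitrophenyl gives a 4.5-fold higher number from compound 1 to compound 4 (0.65 log units; beyond the scatter), so removing the 4-nitrophenyl from the core of compound 1 weakens inhibition by a modest margin beyond the scatter. Nothing available explains why the step has this size.

The compounds shown leave open whether the step follows the aromatic ring itself or the nitro group on it, which an unsubstituted phenyl on the core of compound 1 would separate. They also leave open how a pyridyl ring or a longer chain such as propyl would fare at this place.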